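The source may hold more compounds than are shown below. What is called first, only, known or untested is meant among the compounds shown, and "the series" means these compounds.

Working notes on the series, with all values from a functional assay on LUC1 cells (Homo sapiens) for cytotoxicity, read by sulforhodamine B assay, with a stated time of 48 h (on this read-out lower numbers stand for an effect already at smaller amounts and higher numbers for an effect only at larger amounts of compound), as measured so far

compound 1 `CCCC[C@H](OC(C)=O)[C@@H](O)[C@H](O)[C@@H]1OC(=O)C=C[C@@H]1OC(C)=O` gives 8.8 ug/mL
compound 2 `CCCC[C@@H](/C=C\[C@@H]1OC(=O)C[C@@H](OC)[C@@H]1O)OC(C)=O` gives > 20 ug/mL
compound 3 `CCCC[C@H](OC(C)=O)[C@@H](OC(C)=O)[C@H](OC(C)=O)[C@H]1CC=CC(=O)O1` gives 3.9 ug/mL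

Compound 3 at 3.9 ug/mL holds the lowest of the two actual numbers in the series. Compound 1 stands nearest at 8.8 ug/mL on the higher side, and that gap lies beyond the scatter. Compound 2 gives > 20 ug/mL as a limit of the assay and not a number.

Compound 4 `CCCC[C@H](OC(C)=O)[C@@H](OC(C)=O)[C@H](OC(C)=O)[C@@H]1OC(=O)C=C[C@@H]1OC(C)=O` has not yet been measured and differs from compound 3 by acetoxy in place of hydrogen on a saturated ring carbon with acetoxy in place of hydrogen on a saturated ring carbon, next to the ring atom that bears a large group. Within the data shown here, no measured pair isolates this change. The expectation therefore rests on compound 3 at 3.9 ug/mL and stays close to it, with a wide range on so thin a basis. In this assay the expected size is a 1.1-fold lower number from compound 3 to compound 4 (0.05 log units; within the scatter) and this estimated step lies within the scatter, with no firm direction. For compound 4 the expected value is 3.5 ug/mL with an estimated range from 1.2 ug/mL to 10 ug/mL in this series.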

Compound 4, concentration for half-maximal effect: 7.6 ug/mL
Compound 4: the middle estimate sits 2.2-fold (0.34 log units) below what was measured; the range from low to high includes it.
By their numbers in this assay, from the lowest: compounds 3, 4 and 1 (each within the scatter of the next, the first and the last beyond it). At a limit, above all of these: compound 2.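

In this assay, acetoxy in place of hydrogen on a saturated ring carbon, next to the ring atom that bears a large group, gives a 1.9-fold higher number from compound 3 to compound 4 (0.29 log units; within the scatter), so at this position the added acetoxy brings no change that can be told from the scatter. Among these compounds, this is the first step that can be read at all, as the earlier compounds offered no pair differing in one place, and it gives this position its first direct reading, though one step on one pair cannot support a pattern. The only limit in the series belongs to compound 2 and touches neither compound of this step: the limit of > 20 ug/mL in this assay, at which 1 of the 4 values shown sits.

The compounds shown leave open whether an amine or a benzoyloxy group at this position would also stay within the scatter of compound 3. Among the compounds shown here, also open is whether acetoxy at this position would give a similar step on the core of compound 1, as no pair around that core differs in this one place.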